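A few compounds are considered here, and "the series" means these few. Any claim that something is new, unique, unknown or untested is made for them only; others in the source may bear on it.

Compound 1 `O=C(NCc1ccc(F)cc1)c1nc(Br)c2cccnc2c1NCc1ccccc1`: in a functional assay on HCT-116 cells (Homo sapiens) for cytotoxicity, read by MTT assay, with a stated time of 72 h (a higher number here means a weaker inhibitor, a lower number a stronger inhibitor), compound 1 gives > 20000 nM, which is a limit of the assay rather than a number.
Compound 2 `CS(=O)(=O)Oc1c(C(=O)NCc2ccc(F)cc2)nc(Br)c2cccnc12`: in this assay compound 2 gives > 20000 nM, again a limit rather than a number.
Compound 3 `Nc1ccc(Nc2c(C(=O)NCc3ccc(F)cc3)nc(Br)c3cccnc23)cc1`: in this assay compound 3 gives 7000 nM.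

Compound 3 thus stands as the only one of the three with an actual number; the other two sit at the limit (the limit of > 20000 nM in this assay, at which 2 of the 3 values shown sit). The step from compound 1 to compound 3 was an at least 2.8-fold lower number from compound 1 to compound 3 (0.45 log units; beyond the scatter), and that from compound 2 to compound 3 was an at least 2.8-fold lower number from compound 2 to compound 3 (0.45 log units; beyond the scatter), so the (4-aminophenyl)amino group is what separated a readable number from the limit.

Compound 4 `NCCNc1c(C(=O)NCc2ccc(F)cc2)nc(Br)c2cccnc12` differs from compound 3 in that (2-aminoethyl in place of 4-aminophenyl on a nitrogen on an aromatic ring). Going by the values given here, no measured step replaces a ring by a chain at this place; the two steps that touch it show only that compounds without the (4-aminophenyl)amino group stayed at the limit. The expected step is therefore a 2.1-fold higher number from compound 3 to compound 4 (0.33 log units; beyond the scatter), back toward weaker inhibition. Compound 4 is expected to give about 15000 nM in this assay, with a likely range from 5000 nM to 40000 nM.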

Compound 4, half-maximal inhibitory concentration: > 20000 nM
Compound 4: no number, only a limit; the forecaster's own chance of this, stated with the estimate: 45%; middle value at least 1.3-fold (0.12 log units) from the limit.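

In this assay, replacing the aromatic ring of the 4-aminophenyl group with the open 2-aminoethyl chain gives an at least 2.8-fold higher number from compound 3 to compound 4 (0.45 log units; beyond the scatter). Both groups carry an amino group on the same nitrogen, so an amino group alone does not bring a readable number in this series; of the four compounds, only compound 3 gives one. Compound 4 gives a limit, not a number, and joins the other compounds there: the limit of > 20000 nM in this assay, at which 3 of the 4 values shown sit.

The steps from compound 1 and compound 2 to compound 4 cannot be read, as both ends of each are limits. Still open, as far as these compounds go, is how much of the value of compound 3 depends on the ring and how much on its amino group, which a plain phenyl or a 4-hydroxyphenyl group could test, and whether a longer chain such as 3-aminopropyl would behave like 2-aminoethyl.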